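Dichlorophenyl variant of the hydroxyphenyl pyridyl ketone series

A few compounds are considered here, and "the series" means these few. Any claim that something is new, unique, unknown or untested is made for them only; others in the source may bear on it.

Measured so far in a functional assay on IMR-32 cells (Homo sapiens) for cytotoxicity, read by sulforhodamine B assay, with a stated time of 48 h; on this read-out lower numbers stand for stronger inhibition and higher numbers for weaker inhibition:
- compound 1 `C=CCOc1c(Cl)cc(Cl)cc1C(=O)c1cccnc1`: 52000 nM
- compound 2 `O=C(c1cccnc1)c1cccc(Cl)c1O`: 26000 nM
- compound 3 `O=C(c1cccnc1)c1cc(Cl)ccc1O`: 19500 nM

Compound 3 carries the smallest number of the three, but its gap to compound 2 is within the scatter, so the two cannot be ranked against each other; only its gap to compound 1 lies beyond the scatter. The next compound, compound 4 `O=C(c1cccnc1)c1cc(Cl)cc(Cl)c1O`, is to be measured in this assay. It differs from compound 3 at one point: chloro in place of hydrogen on an aromatic carbon. The change is the entry of a chloro in place of a hydrogen on an aromatic carbon, ortho to the hydroxy group and meta to the chloro group already present.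

For the measured compounds named here, no step between two measured compounds matches this change, so there is no directly comparable precedent. Compound 2, which carries a chloro ortho to its hydroxy group, sits at 26000 nM, close to compound 3. The expectation for the step from compound 3 to compound 4 is therefore small, a 1.2-fold lower number from compound 3 to compound 4 (0.09 log units; within the scatter), and not clearly beyond the scatter in either direction. Compound 4 is estimated at 16000 nM, with a range from 6000 nM to 40000 nM.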

Compound 4, half-maximal inhibitory concentration: 28800 nM
Beside the measured number, compound 4's estimate is 1.8-fold (0.26 log units) below it, and the stated range covers the measured number.
By their numbers in this assay, from the lowest: compounds 3, 2, 4 and 1 (each within the scatter of the next, the first and the last beyond it).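

In this assay, a chloro entering ortho to the hydroxy group and meta to the chloro group already present gives a 1.5-fold higher number from compound 3 to compound 4 (0.17 log units; within the scatter), and the entry of a chloro on compound 2 gives a 1.1-fold higher number from compound 2 to compound 4 (0.04 log units; within the scatter); both steps lie within the scatter, so neither single-chloro compound can be separated from compound 4, which stands at 28800 nM, and a second chloro on this ring gives no readable change in either case. Hydrogen in place of allyl on the oxygen gives a 1.8-fold lower number from compound 1 to compound 4 (0.26 log units; within the scatter), also within the scatter, so with two chloro groups on the ring, the free hydroxy compound and its allyl ether cannot be told apart, even though compound 1 stands beyond the scatter from compound 3. Nothing available accounts for these numbers or connects them to any property of the compounds.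

From the compounds shown here alone, whether an amine or a carboxylic acid in place of the chloro at this position would give a step beyond the scatter stays open. Also open, going by these compounds, is whether a longer chain than allyl on the oxygen, or a methyl there, would separate from compound 4.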